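A few compounds are considered here, and "the series" means these few. Any claim that something is new, unique, unknown or untested is made for them only; others in the source may bear on it.

The measured compounds and their values in a functional assay on the whole organism (strain Wister albino) for inhibition, with Rattus norvegicus as the target, read by paw edema, with stated times of 30 min and 3 h, at a dose of 10 mg/kg by the oral route; on this read-out higher numbers stand for more inhibition at the one dose given (going by the name of the read-out) and lower numbers for less inhibition:
compound 1, `CCOC(=O)C1CCN(Cn2nc(Cc3ccc(SC)cc3)oc2=S)CC1`, 57.4%
compound 2, `CC(C)Cc1ccc(C(C)c2nn(CN3CCN(c4ccc(Cl)cc4)CC3)c(=S)o2)cc1`, 76.6%
compound 3, `CC(C)Cc1ccc(C(C)c2nn(CN3CCN(c4cccc(Cl)c4)CC3)c(=S)o2)cc1`, 64.3%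

Compound 3 stands second highest of the three numbers in this assay. Its nearest neighbour is compound 1, whose value lies within the scatter of that of compound 3, so no order between those two can be read. Going by the values given here, compound 2 lies furthest away: a number 12.3 percentage points lower from compound 2 to compound 3 (beyond the scatter), the one single-place step among the measured compounds.

Compound 4, `CC(C)Cc1ccc(C(C)c2nn(CN3CCN(c4ccc(F)cc4)CC3)c(=S)o2)cc1`, differs from compound 3 in one place: 4-fluorophenyl in place of 3-chlorophenyl on an amine nitrogen in a ring. The 4-fluorophenyl of compound 4 resembles the 4-chlorophenyl of compound 2 more than it does the 3-chlorophenyl of compound 3, with fluorine standing where compound 2 has chlorine. The step from compound 2 to compound 3 is the only measured one that bears on this change, and it was modest. Among the compounds with values here, no measured pair shows what exchanging chlorine for fluorine does, so that part of the change is unknown. A step upward from compound 3 to compound 4 is therefore expected, but a small one, likely within the scatter, and compound 4 is estimated at 70%, between 58% and 80%, which means an expected step of a number 5.7 percentage points higher from compound 3 to compound 4 (within the scatter).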

Compound 4, a percentage reported as inhibition, in the whole organism at one dose (the size of the read-out at that dose, not a potency): 75.4%
Estimate against measurement, compound 4: 5.4 percentage points below, within the range that was stated.
By their numbers in this assay, from the lowest: compounds 1 and 3 (each within the scatter of the next); then compounds 4 and 2 (each within the scatter of the next).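

In this assay, 4-fluorophenyl in place of 3-chlorophenyl on the amine nitrogen in a ring gives a number 11.1 percentage points higher from compound 3 to compound 4 (beyond the scatter) and so runs opposite in direction to the earlier a number 12.3 percentage points lower from compound 2 to compound 3 (beyond the scatter) on the same place. Fluoro in place of chloro on the aromatic carbon gives a number 1.2 percentage points lower from compound 2 to compound 4 (within the scatter) and thus shows for the first time that this exchange makes no readable difference here. Compound 2 and compound 4, with 4-chlorophenyl and 4-fluorophenyl, therefore both stand apart from compound 3 with its 3-chlorophenyl.

The compounds shown leave open whether the drop seen with 3-chlorophenyl would recur with 3-fluorophenyl, since only chloro has been seen in that place. They also leave open what a methoxy group or a carboxylic acid on this phenyl ring would give. Nothing at hand explains any of these steps.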